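A few compounds are considered here, and "the series" means these few. Any claim that something is new, unique, unknown or untested is made for them only; others in the source may bear on it.

The compounds measured so far:

compound 1 `O=C(c1cccc(OC(F)(F)F)c1)N1CCC(N(C2CC2)S(=O)(=O)c2cccc(C(F)(F)F)c2)CC1` 370 nM
compound 2 `COc1cccc(OC)c1CN1CCC(N(C2CC2)S(=O)(=O)c2cccc(C(F)(F)F)c2)CC1` 60 nM
compound 3 `O=C(c1ccccc1OC(F)(F)F)N1CCC(N(C2CC2)S(=O)(=O)c2cccc(C(F)(F)F)c2)CC1` 120 nM

The assay is an assay on HEK293 cells for inhibition of Voltage-dependent N-type calcium channel subunit alpha-1B (Homo sapiens), read by FLIPR and calcium flux, in the presence of a further agent that is not named here; on this read-out lower numbers stand for stronger inhibition and higher numbers for weaker inhibition. Among the three numbers, compound 3 stands second highest. Its nearest neighbour is compound 2, whose value of 60 nM lies within the scatter of compound 3's 120 nM; the two cannot be ordered. The furthest is compound 1, and the step of a 3.1-fold lower number from compound 1 to compound 3 (0.49 log units; beyond the scatter) lies beyond the scatter.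

Compound 4 `CN(C)c1cccc(C(=O)N2CCC(N(C3CC3)S(=O)(=O)c3cccc(C(F)(F)F)c3)CC2)c1` differs from compound 3 in one place: 3-(dimethylamino)phenyl in place of 2-(trifluoromethoxy)phenyl on a carbonyl carbon. Going by the values given here, only one measured step bears on this change, the step of a 3.1-fold lower number from compound 1 to compound 3 (0.49 log units; beyond the scatter), and it bears on it indirectly: it shows that moving the trifluoromethoxy group from the 3-position to the 2-position lowered the number. Compound 4 returns a substituent to the 3-position but of a different kind, a dimethylamino group, for which no measurement exists. Compound 3 is therefore expected to lose some ground in the step of a 2.1-fold higher number from compound 3 to compound 4 (0.32 log units; beyond the scatter), though the size is uncertain. Compound 4 is expected to give about 250 nM, with a range from 80 nM to 800 nM.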

Compound 4, half-maximal inhibitory concentration: 240 nM
Compound 4: the middle estimate sits 1.0-fold (0.02 log units) above what was measured, and the stated range covers the measured number.
By their numbers in this assay, from the lowest: compounds 2, 3, 4 and 1 (each within the scatter of the next, the first and the last beyond it).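

In this assay, the first non-trifluoromethoxy substituent on this carbonyl-bound phenyl gives a 2.0-fold higher number from compound 3 to compound 4 (0.30 log units; within the scatter), and dimethylamino in place of trifluoromethoxy on an aromatic carbon gives a 1.5-fold lower number from compound 1 to compound 4 (0.19 log units; within the scatter), so neither pair can be ordered. Going by these compounds alone, the only step here beyond the scatter is a 4.0-fold higher number from compound 2 to compound 4 (0.60 log units; beyond the scatter), with (3-(dimethylamino)phenyl)carbonyl in place of 2,6-dimethoxybenzyl on an amine nitrogen in a ring, but this change alters the carbonyl and the phenyl substituents together and cannot assign the difference to either. No available evidence bears on the cause of these steps.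

The compounds shown leave open whether 2,6-dimethoxyphenyl on the same carbonyl would separate the contribution of the carbonyl from that of the methoxy groups. From the compounds shown here alone, it also remains open whether a primary amine or a carboxylic acid in place of dimethylamino would give a step beyond the scatter.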